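Moving a Methyl Along the Chloroaryl Side Chain

A few compounds are considered here, and "the series" means these few. Any claim that something is new, unique, unknown or untested is made for them only; others in the source may bear on it.

Compound 1 `Cc1cc(Cl)ccc1CC(C)C(=O)N1CCN(c2ccc(C(F)(F)F)cc2[C@@H](N)CC(C)C)CC1` gives 38 nM in an assay on HEK293 cells for displacement of a labelled ligand from Melanocortin receptor 4 (Homo sapiens) (on this read-out lower numbers stand for stronger inhibition and higher numbers for weaker inhibition), the lowest of the three numbers measured. Compound 2 `CC(C)C[C@H](N)c1cc(C(F)(F)F)ccc1N1CCN(C(=O)COc2ccc(O)cc2)CC1` gives 4600 nM and compound 3 `CC(C)C[C@H](N)c1cc(C(F)(F)F)ccc1N1CCN(C(=O)CNc2ccccc2)CC1` gives 3600 nM; the steps of a 120-fold higher number from compound 1 to compound 2 (2.08 log units; beyond the scatter) and a 95-fold higher number from compound 1 to compound 3 (1.98 log units; beyond the scatter) show that exchanging the whole side chain costs a great deal, while a 1.3-fold lower number from compound 2 to compound 3 (0.11 log units; within the scatter). Compound 4 `Cc1cc(CC(C)C(=O)N2CCN(c3ccc(C(F)(F)F)cc3[C@@H](N)CC(C)C)CC2)ccc1Cl` differs from compound 1 only in that (4-chloro-3-methylphenyl in place of 4-chloro-2-methylphenyl on a saturated chain carbon, two bonds along the chain from a carbonyl carbon). Among the compounds with values here, no measured step moves the methyl alone; the large steps bear on the side chain as a whole and say nothing about this smaller change. A small step, within the scatter or slightly weaker, is therefore expected: a 1.6-fold higher number from compound 1 to compound 4 (0.20 log units; within the scatter). Compound 4 is estimated at 60 nM, with a range of 20 nM to 200 nM.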

Compound 4, inhibition constant: 71 nM
Compound 4: the middle estimate sits 1.2-fold (0.07 log units) below what was measured; measured number inside the range.
By their numbers in this assay, from the lowest: compounds 1 and 4 (each within the scatter of the next); then compounds 3 and 2 (each within the scatter of the next).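

Shifting the methyl, from 4-chloro-2-methylphenyl to 4-chloro-3-methylphenyl, gives a 1.9-fold higher number from compound 1 to compound 4 (0.27 log units; within the scatter) in this assay, so the two placings cannot be told apart at this position. The large gap to the other side chains also holds with the shifted methyl, at a 51-fold lower number from compound 3 to compound 4 (1.71 log units; beyond the scatter) and a 65-fold lower number from compound 2 to compound 4 (1.81 log units; beyond the scatter). Nothing available explains why the shift is so well accepted.

On these data alone, it remains open what a methoxy group or a fluorine in place of the methyl would give, and whether a nitrile could stand in for the chlorine.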